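Replacing 4-fluorobenzyl with cyclobutyl

The source may report more compounds than this note shows. Statements on the series, on what has been measured and on what is new or still open speak of the compounds shown alone.

Measured in a functional assay on RAW264.7 cells (Mus musculus) for inhibition, read by Griess assay, with stated times of 2 h and 24 h; a higher number here means a weaker inhibitor, a lower number a stronger inhibitor:
- compound 1 `COc1ccc([C@@H]2CC(=O)c3c(O)cc(OCc4cn(Cc5ccc(C(F)(F)F)cc5)nn4)cc3O2)cc1O` gives 17700 nM
- compound 2 `COc1ccc([C@@H]2CC(=O)c3c(O)cc(OCc4cn(Cc5ccc(C)cc5)nn4)cc3O2)cc1O` gives 16800 nM
- compound 3 `COc1ccc([C@@H]2CC(=O)c3c(O)cc(OCc4cn(Cc5ccc(F)cc5)nn4)cc3O2)cc1O` gives 15100 nM

Compound 3, at 15100 nM, cannot be separated from the other two compounds: a 1.2-fold lower number from compound 1 to compound 3 (0.07 log units; within the scatter) and a 1.1-fold lower number from compound 2 to compound 3 (0.05 log units; within the scatter). The third step, a 1.1-fold lower number from compound 1 to compound 2 (0.02 log units; within the scatter), is just as small. All three steps exchange a group on an aromatic carbon and keep the benzyl unit, so they bear only indirectly on the next change.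

Compound 4 `COc1ccc([C@@H]2CC(=O)c3c(O)cc(OCc4cn(C5CCC5)nn4)cc3O2)cc1O` carries cyclobutyl in place of 4-fluorobenzyl on an aromatic nitrogen. Among the measured compounds shown here, no measured compound lacks the benzyl unit, so the data give no direct evidence on its removal and no firm direction for the step. A step within the scatter is nevertheless expected in this assay, estimated as a 1.2-fold higher number from compound 3 to compound 4 (0.08 log units; within the scatter). The range is kept wide to allow for the larger structural change. The estimate for compound 4 is 18000 nM, with an expected range of 8000 nM to 40000 nM.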

Compound 4, half-maximal inhibitory concentration: 15300 nM
Compound 4: the middle estimate sits 1.2-fold (0.07 log units) above what was measured, and the stated range covers the measured number.
By their numbers in this assay, from the lowest: compounds 3, 4, 2 and 1 (each within the scatter of the next).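

The earlier compounds shown here changed only a group on an aromatic carbon and kept the benzyl unit; compound 4 removes that unit from the aromatic nitrogen. In this assay, cyclobutyl in place of 4-fluorobenzyl gives a 1.0-fold higher number from compound 3 to compound 4 (0.01 log units; within the scatter) and the comparisons with the other benzyl groups give a 1.1-fold lower number from compound 2 to compound 4 (0.04 log units; within the scatter) and a 1.2-fold lower number from compound 1 to compound 4 (0.06 log units; within the scatter), so across these four compounds the number does not depend on a six-membered aromatic ring at this position. Nothing available explains why this position tolerates the exchange.

On these data alone, it remains open whether an amine, a carboxylic acid or a longer alkyl chain on this nitrogen would move the number beyond the scatter. The compounds shown also leave open whether changes to the shared core, rather than to this group, would separate the series.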